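Trading the catechol ring for cyclohexyl on a secoiridoid ester

The source may hold more compounds than are shown below. What is called first, only, known or untested is meant among the compounds shown, and "the series" means these compounds.

Of the compounds shown here, two sharing the same core have been measured in a functional assay on MCF7 cells (Homo sapiens) for antiproliferative activity, read by MTT assay, with a stated time of 72 h; on this read-out higher numbers stand for weaker inhibition and lower numbers for stronger inhibition. Compound 1 `C/C=C1/[C@H](O[C@@H]2O[C@H](COC(C)=O)[C@@H](OC(C)=O)[C@H](OC(C)=O)[C@H]2OC(C)=O)OC=C(C(=O)OC)[C@H]1CC(=O)OCCC` carries an acetylated sugar and a short chain ester; in this assay compound 1 gives 15000 nM. Compound 2 `C/C=C1/[C@H](O[C@@H]2O[C@H](CO)[C@@H](O)[C@H](O)[C@H]2O)OC=C(C(=O)OC)[C@H]1CC(=O)OCCc1ccc(O)c(O)c1` keeps the free sugar and a 2-(3,4-dihydroxyphenyl)ethyl ester; in this assay compound 2 gives 162000 nM, the higher of the two numbers, and its gap to compound 1 lies beyond the usual scatter.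

Compound 3 `C/C=C1/[C@H](O[C@@H]2O[C@H](CO)[C@@H](O)[C@H](O)[C@H]2O)OC=C(C(=O)OC)[C@H]1CC(=O)OCCC1CCCCC1` differs from compound 2 in one place: cyclohexyl in place of 3,4-dihydroxyphenyl on a saturated chain carbon, two bonds along the chain from an oxygen next to a carbonyl group. The change removes the two hydrogen-bond donors and two acceptors of the 3,4-dihydroxyphenyl group. Among the measured compounds shown here, no measured pair isolates this change, so its size is uncertain; a moderate fall in the number is expected, because compound 1, whose ester also lacks an aromatic ring, gives 15000 nM. For compound 3 the expected step is a 3.2-fold lower number from compound 2 to compound 3 (0.51 log units; beyond the scatter). The estimate for compound 3 is 50000 nM, within 15000 nM to 160000 nM.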

Compound 3, half-maximal inhibitory concentration: 5000 nM
Compound 3: middle estimate off by 10-fold (1.00 log units), on the high side, and the stated range ends above it.
By their numbers in this assay, from the lowest: compound 3; then compound 1; then compound 2.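

In this assay, cyclohexyl in place of 3,4-dihydroxyphenyl on a saturated chain carbon, two bonds along the chain from an oxygen next to a carbonyl group, gives a 32-fold lower number from compound 2 to compound 3 (1.51 log units; beyond the scatter) and so shows that the read-out responds strongly to the group at this place. Both compounds keep the free sugar, so this step isolates the ester end, which the earlier pair could not do because compound 1 also differs at the sugar. Nothing available here accounts for the size of the step.

The compounds shown do not separate the loss of the two hydroxyl groups from the loss of the aromatic ring, which a plain phenyl at this place would help to divide. From the compounds shown here alone, how a longer chain, or an amine on the cyclohexyl ring, would read also remains open.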